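From Compound 3 to Compound 4: A Step Without a Baseline

The source may report more compounds than this note shows. Statements on the series, on what has been measured and on what is new or still open speak of the compounds shown alone.

Measured so far in a functional assay on MDA-MB-231 cells (Homo sapiens) for inhibition, read by MTT assay, with a stated time of 72 h; a lower number here means a stronger inhibitor, a higher number a weaker inhibitor:
- Compound 1 `O=C1CS/C(=N\c2nc3cc(-c4ccc(Cl)cc4)sc3s2)N1` reads 18800 nM
- Compound 2 `O=C1CS/C(=N\c2nc3cc(-c4ccc(Cl)cc4)[se]c3s2)N1` reads 35600 nM
- Compound 3 `CN(C)c1ccc(/C=C2/S/C(=N\c3nc4cc(-c5ccc(Cl)cc5)sc4s3)NC2=O)cc1` reads "not determined" (no result reported)

The values of compound 1 and compound 2 lie within the usual scatter of each other, so the two cannot be ranked. Compound 3 has no place on this scale, since no result was reported for it. Compound 4 (`O=C1N/C(=N/c2nc3cc(-c4ccc(Cl)cc4)sc3s2)S/C1=C/c1ccc2ccccc2c1`) differs from compound 3 in one place: naphthalen-2-yl in place of 4-(dimethylamino)phenyl on a double-bonded chain carbon bound to a double-bonded ring carbon. In words, naphthalen-2-yl stands in place of 4-(dimethylamino)phenyl on a double-bonded chain carbon bound to a double-bonded ring carbon.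

Without a number for compound 3, the size of this step in this assay cannot be read directly. Within the data shown here, the expectation therefore leans on the only numbers available, those of compound 1 (18800 nM) and compound 2 (35600 nM). Against these, a modest move toward stronger inhibition is expected, perhaps no larger than the scatter, and the uncertainty remains wide. The expected value for compound 4 is 15000 nM, within an estimated range from 4000 nM to 50000 nM.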

Compound 4, half-maximal inhibitory concentration: > 50000 nM
Compound 4 gave a limit, no number; the forecaster's own chance of this, stated with the estimate: 20%; middle value at least 3.3-fold (0.52 log units) from the limit.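

Among these compounds, compound 3 has no reported result in this assay, and the reading for compound 4, > 50000 nM, is a limit and not a number, so no step between them can be read. The compounds shown leave open how far naphthalen-2-yl in place of 4-(dimethylamino)phenyl shifts inhibition in this assay, and in which direction.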